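Methoxy removal on the aryl ketone ring of the series

The source may report more compounds than this note shows. Statements on the series, on what has been measured and on what is new or still open speak of the compounds shown alone.

Compound 1 `COc1ccc(-c2cc(/C=C/C(=O)c3ccc(N)cc3)[nH]n2)cc1` and compound 2 `COc1ccc(-c2cc(/C=C/C(=O)c3ccc(N)cc3)[nH]n2)cc1OC` differ in one place. In a functional assay on 786-0 cells (Homo sapiens) for cytotoxicity, read by sulforhodamine B assay, with a stated time of 48 h, tested at 0.01 uM (on this read-out lower numbers stand for a stronger effect and higher numbers for a weaker effect at the one concentration tested), compound 1 gives 96% and compound 2 gives 91%. The change between them is hydrogen in place of methoxy on an aromatic carbon and the step it made is a number 5 percentage points higher from compound 2 to compound 1 (within the scatter). Compound 3 `COc1cc(C(=O)/C=C/c2cc(-c3cc(OC)c(OC)c(OC)c3)n[nH]2)cc(OC)c1OC` gives 101% in this assay; the difference between the core of compound 3 and the core of compound 2 is not broken down here, so of these two only their values are noted, and they lie close to each other.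

Compound 4 `COc1ccc(-c2cc(/C=C/C(=O)c3cc(OC)c(OC)c(OC)c3)[nH]n2)cc1OC` is not yet measured. It differs from compound 3 by hydrogen in place of methoxy on an aromatic carbon. In the earlier pair the aromatic carbon that loses the methoxy is ortho to a methoxy group and meta to a large group; in compound 3 it is in addition meta to a methoxy group, so this is the same kind of change, not the same one.

The step from compound 3 to compound 4 is estimated at a number 3 percentage points lower from compound 3 to compound 4 (within the scatter), resting on the small step of a number 5 percentage points higher from compound 2 to compound 1 (within the scatter) seen for the same kind of change. Compound 4 is therefore expected to give 98% in this assay, with an expected range from 88% to 108%.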

Compound 4, a percentage reported as activity, at one concentration (the size of the read-out at that concentration, not a potency): 100%
For compound 4 the middle estimate is 2 percentage points below the measured one, and the stated range covers the measured number.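

Hydrogen in place of methoxy on an aromatic carbon gives a number 1 percentage points lower from compound 3 to compound 4 (within the scatter) in this assay. Set beside the earlier step, the change shows no difference between the two cores: the same change on two cores in this assay, a number 5 percentage points higher (within the scatter) from compound 2 to compound 1 and a number 1 percentage points lower (within the scatter) from compound 3 to compound 4, 6 percentage points apart, within the scatter of two such steps This shows that on both cores the change leaves the read-out within the scatter at the one concentration tested, but not that methoxy at this place is without effect in general, since a single concentration gives no potency and two cores say nothing about a third.

The compounds shown leave open whether a group other than methoxy or hydrogen at this place, such as a hydroxyl, a chlorine or a longer ethoxy chain, would move the read-out on either core. Also open is whether the two steps would still agree at a concentration where the read-out of these compounds departs from the narrow band seen here.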